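Fluoro to Chloro on the Cinnamamide Aryl Ring

The source may report more compounds than this note shows. Statements on the series, on what has been measured and on what is new or still open speak of the compounds shown alone.

Compound 1, `CCCc1cc(NC2CC2)c2cc(NC(=O)/C=C/c3ccc(C(F)(F)F)cc3)ccc2n1`, gives 40 nM.
Compound 2, `CCCc1cc(N)c2cc(NC(=O)/C=C/c3ccc(F)cc3)ccc2n1`, gives 130 nM.

Both compounds were tested in an assay on isolated protein for displacement of a labelled ligand from melanin-concentrating hormone receptor 1 (Homo sapiens); a lower number here means a stronger inhibitor, a higher number a weaker inhibitor. Compound 2 stands at the higher of the two numbers; compound 1 sits at a lower number, and the gap between them lies beyond the scatter of repeated measurements, so compound 1 is the stronger inhibitor of the pair. The two compounds differ in more than one place, so the gap cannot be tied to a single change.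

Compound 3, `CCCc1cc(N)c2cc(NC(=O)/C=C/c3ccc(Cl)cc3)ccc2n1`, has not yet been measured. It is built from compound 2 by a single change: chloro in place of fluoro on an aromatic carbon. For the measured compounds named here, nothing measured here isolates this exchange, so there is no step to lean on directly. The expected outcome for compound 3 is a modest move toward a lower number, by a 1.6-fold lower number from compound 2 to compound 3 (0.21 log units; within the scatter), a step that may well fall within the scatter. Compound 3 is therefore estimated at 80 nM, with a range from 30 nM to 250 nM.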

Compound 3, half-maximal inhibitory concentration: 6 nM
The estimate for compound 3 lay 13-fold (1.12 log units) above the measured number; measured number below the stated range.
By their numbers in this assay, from the lowest: compound 3; then compound 1; then compound 2.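

Going from 4-fluorophenyl to 4-chlorophenyl in this assay brings a 22-fold lower number from compound 2 to compound 3 (1.34 log units; beyond the scatter) and is the first step here that can be tied to one change. Compound 1 and compound 2 differ in more than one place, so they could not show that this spot on the aromatic ring, para to a large group, matters on its own; here, swapping one heavy atom for one heavy atom, with no hydrogen-bond donors or acceptors and no net charge on either side, moves the number well beyond the scatter. No measurement shown here accounts for so large a step from so small an exchange, and its cause remains unknown.

From the compounds shown here alone, whether bromo, a methyl group or a nitrile at the same spot would lower the number further or raise it again remains open. Compound 1 carries trifluoromethyl at this spot together with a cyclopropyl group on the amine of the shared core, so what each of those two groups does alone cannot be read.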